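The compounds below may be only part of what the source reports. "The series", "measured", "known", "first", "only" and "open" are said of these compounds alone.

Of the compounds shown here, two have so far been tested in a functional assay on MCF7 cells (Homo sapiens) for cytotoxicity, read by MTT assay, with a stated time of 4 days; on this read-out lower numbers stand for stronger inhibition and higher numbers for weaker inhibition. Compound 1 `C=C1C(=O)[C@]23C[C@@]1(O)CC[C@H]2c1ccc(OS(=O)(=O)c2ccc(C)cc2)c(C)c1[C@@H]3Cn1cc(-c2ccc(Cl)cc2)nn1` gives 1440 nM there, while compound 2 `C=C1C(=O)[C@]23C[C@@]1(O)CC[C@H]2c1ccc(O)c(C)c1[C@@H]3Cn1cc(-c2ccc(C)cc2)nn1` gives 370 nM, the lowest of the two numbers and clearly apart from compound 1. Compound 3 `C=C1C(=O)[C@]23C[C@@]1(O)CC[C@H]2c1ccc(OS(=O)(=O)c2ccc(C)cc2)c(C)c1[C@@H]3Cn1cc(-c2ccc(C)cc2)nn1` has not been measured yet; it differs from compound 2 by (4-methylphenyl)sulfonyl in place of hydrogen on an oxygen on an aromatic ring. Going by the values given here, compound 1 and compound 2 differ in two places at once, so no single step isolates this change. The number is expected to rise, with an estimated step of a 2.7-fold higher number from compound 2 to compound 3 (0.43 log units; beyond the scatter). Compound 3 is therefore expected to give 1000 nM, within a range of 400 nM to 2500 nM.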

Compound 3, half-maximal inhibitory concentration: 320 nM
The estimate for compound 3 lay 3.1-fold (0.49 log units) above the measured number, and the stated range ends above it.
By their numbers in this assay, from the lowest: compounds 3 and 2 (each within the scatter of the next); then compound 1.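

In this assay, replacing hydroxy with ((4-methylphenyl)sulfonyl)oxy gives a 1.2-fold lower number from compound 2 to compound 3 (0.06 log units; within the scatter), so adding these 10 heavy atoms on the oxygen leaves the number within the scatter. Methyl in place of chloro on an aromatic carbon, now seen as a single change, gives a 4.5-fold lower number from compound 1 to compound 3 (0.65 log units; beyond the scatter), a modest step beyond the scatter. Nothing available explains either result. On these data alone, it remains open whether other groups on this oxygen, such as methyl or acetyl, would also stay within the scatter. Methoxy or fluoro in place of methyl on that aromatic carbon also remains untested among these compounds.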